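The compounds below may be only part of what the source reports. "The series", "measured", "known", "first", "only" and "open" are said of these compounds alone.

Compound 1 `Cc1cc(C#N)cc(C)c1Oc1ccnc(SCC(=O)Nc2ccc(C#N)cc2)n1`: > 300000 nM, a limit of the assay, not a number
Compound 2 `Cc1cc(C#N)cc(C)c1Oc1ccnc(S(=O)(=O)CC(=O)Nc2ccccc2F)n1`: 28400 nM

Both entries come from an ADME assay on MT4 cells (Homo sapiens) for cytotoxicity, read by MTT assay, with a stated time of 4 days; a higher number here means that more compound is tolerated, a lower number that less compound is tolerated. Going by the values given here, compound 2 holds the only true number in this small set, since the one other entry is a limit, so no ranking or spread can be drawn from the series yet. Compound 3 `Cc1cc(C#N)cc(C)c1Oc1ccnc(S(=O)(=O)CC(=O)Nc2ccc(Cl)cc2Cl)n1` keeps the rest of compound 2 and changes one group: 2,4-dichlorophenyl in place of 2-fluorophenyl on an amide-type nitrogen. In words, 2,4-dichlorophenyl stands in place of 2-fluorophenyl on an amide-type nitrogen. Among the compounds with values here, no measured pair here isolates this change, so the expectation is anchored on the closest neighbour, compound 2 at 28400 nM, and stays cautious. A modest move towards less compound being tolerated in this assay is expected, of a size not far beyond the usual scatter, and no change at all would be no surprise. The expected change is a 1.9-fold lower number from compound 2 to compound 3 (0.28 log units; within the scatter). For compound 3 the estimated value is 15000 nM, with an expected range from 5000 nM to 45000 nM.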

Compound 3, half-maximal cytotoxic concentration: 10400 nM
For compound 3 the middle estimate is 1.4-fold (0.16 log units) above the measured one; the measured number falls inside the stated range.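

In this assay, the group on the amide-type nitrogen now proves able to move the read-out: 2,4-dichlorophenyl in place of 2-fluorophenyl gives a 2.7-fold lower number from compound 2 to compound 3 (0.44 log units; beyond the scatter) and so less compound is tolerated. Going by these compounds alone, this is the only readable step, and compound 2 alone could not show that a change at this place registers at all, though a single modest step gives no trend. Within the data shown here, compound 1 stands at > 300000 nM, a limit of the assay and not a number, and it differs from compound 3 in more than one place, so it adds no step at this position.

No measurement at hand bears on why the number moves in this step.

Going by these compounds, whether the change follows the added chlorine atoms or the departure of fluorine stays open, and a 2-chlorophenyl or 4-chlorophenyl group on the same nitrogen would separate the two. Also open, on these data alone, is how the read-out would respond to a group of another kind at this place, such as a methoxyphenyl, a pyridyl ring or a saturated amine such as piperidine.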